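A Carbamate in Place of the Difluorobenzamide

The source may report more compounds than this note shows. Statements on the series, on what has been measured and on what is new or still open speak of the compounds shown alone.

Of the compounds shown here, two sharing one core have been measured in an assay on CHO-K1 cells for displacement of a labelled ligand from prostaglandin E2 receptor EP1 subtype (Homo sapiens); on this read-out lower numbers stand for stronger inhibition and higher numbers for weaker inhibition. Compound 1 `Cc1cc(C(=O)NC(C)C)nn1Cc1cc(Cl)ccc1OCc1ccccc1` gives 126 nM. Within the data shown here, compound 2 `Cc1cc(NC(=O)c2c(F)cccc2F)nn1Cc1cc(Cl)ccc1OCc1ccccc1` gives 12.6 nM, the lowest of the two numbers, and the single measured step, a 10-fold lower number from compound 1 to compound 2 (1.00 log units; beyond the scatter), separates them. Compound 3 `Cc1cc(NC(=O)OCc2ccccn2)nn1Cc1cc(Cl)ccc1OCc1ccccc1` differs from compound 2 in one place: (pyridin-2-yl)methoxy in place of 2,6-difluorophenyl on a carbonyl carbon. Among the measured compounds shown here, no measured step touches this carbonyl carbon; the step already known alters the group on the other side of the amide-type nitrogen and therefore gives no direct guide to the present change. On the two measured compounds alone, a modest rise in the number is expected in this assay. Compound 3 is estimated at 40 nM, with a range from 10 nM to 160 nM, which is expected to mean a 3.2-fold higher number from compound 2 to compound 3 (0.50 log units; beyond the scatter) in this assay.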

Compound 3, half-maximal inhibitory concentration: 79.4 nM
Beside the measured number, compound 3's estimate is 2.0-fold (0.30 log units) below it; measured number inside the range.
By their numbers in this assay, from the lowest: compound 2; then compounds 3 and 1 (each within the scatter of the next).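

In this assay, (pyridin-2-yl)methoxy in place of 2,6-difluorophenyl on the carbonyl carbon gives a 6.3-fold higher number from compound 2 to compound 3 (0.80 log units; beyond the scatter), so the number responds to the group carried at this carbonyl carbon, which the earlier step could not show. Against the isopropylcarbamoyl compound, the change to (((pyridin-2-yl)methoxy)carbonyl)amino gives a 1.6-fold lower number from compound 1 to compound 3 (0.20 log units; within the scatter), so the gain seen with compound 2 is not retained by compound 3. Nothing available gives a reason for this loss.

The change alters the ring and the link to the carbonyl carbon together, and the compounds shown do not separate the two. From the compounds shown here alone, it remains open whether a plain benzyloxy group on this carbonyl carbon would give a number like that of compound 2 or like that of compound 3.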